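The compounds below may be only part of what the source reports. "The series", "measured", "known", "first", "only" and "open" are said of these compounds alone.

Three compounds have been measured in a functional assay on the whole organism with Mus musculus as the target; on this read-out lower numbers stand for an effect already at smaller amounts and higher numbers for an effect only at larger amounts of compound:

compound 1 `CCCN1C(=O)CCC1(O)c1cccc(C(F)(F)F)c1` — compound 1 gives > 200 mg/kg, which is a limit of the assay and not a number;
compound 2 `CCCCN1C(=O)CCC1(O)c1cccc(C(F)(F)F)c1` — compound 2 gives > 200 mg/kg, again a limit of the assay;
compound 3 `CC(C)NC(=O)CCC(=O)c1cccc(C(F)(F)F)c1` — compound 3 gives > 200 mg/kg, also a limit of the assay.

Compound 1 and compound 2 differ in one place: methyl in place of hydrogen on a saturated chain carbon, three bonds along the chain from an amide-type nitrogen in a ring. The step that the two limits leave unreadable from compound 1 to compound 2 has no readable size because both ends sit at the limit of > 200 mg/kg in this assay, at which 3 of the 3 values shown sit.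

Compound 3 is built from the same atoms as compound 1, joined differently; the difference between the two cores is not broken down here.

Compound 4 `CCC(C)NC(=O)CCC(=O)c1cccc(C(F)(F)F)c1` has not been measured yet. It differs from compound 3 by methyl in place of hydrogen on a saturated chain carbon, two bonds along the chain from an amide-type nitrogen. For the measured compounds named here, this is the same kind of change as the one from compound 1 to compound 2, but not the same change: in compound 1 the new methyl sits three bonds along the chain from an amide-type nitrogen in a ring, whereas in compound 3 it sits two bonds along the chain from an amide-type nitrogen.

Compound 4 is expected to give about 250 mg/kg, within an estimated range from 100 mg/kg to 1000 mg/kg, and will most likely again be reported as a limit rather than a number. The expected step that the limit leaves unreadable from compound 3 to compound 4 is close to none. This expectation rests on compound 3, which gives > 200 mg/kg. Going by the values given here, it also rests on (the limit of > 200 mg/kg in this assay, at which 3 of the 3 values shown sit), where every value measured so far sits.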

Compound 4, dose for half-maximal effect: > 200 mg/kg
Compound 4 gave a limit, no number; the forecaster's own chance of this, stated with the estimate: 80%; the middle value does not contradict the limit.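

In this assay compound 4 gives > 200 mg/kg, which is a limit of the assay and not a number. Compound 3 sits at the same limit, so no step can be read between compound 3 and compound 4. The compounds shown leave open how strongly, if at all, any of them acts at a dose that could be given as a number, since all of them end at one point: the limit of > 200 mg/kg in this assay, at which 4 of the 4 values shown sit.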